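This account rests on a few compounds, and the source may have more. Where it says the series, first, only, none or still open, it means among the compounds named here.

Compound 1 `Cc1cc(S(=O)(=O)/N=C(\N)n2nccc2-c2ccccc2)c(SCc2ccccc2)cc1Cl` is the reference point of this small set. In a functional assay on HCT-116 cells (Homo sapiens) for cytotoxicity, read by MTT assay, with a stated time of 72 h (on this read-out lower numbers stand for stronger inhibition and higher numbers for weaker inhibition), compound 1 gives 12000 nM. Compound 2 `Cc1cc(S(=O)(=O)/N=C(\N)n2nccc2-c2ccccc2)c(SCc2ccccc2C)cc1Cl` differs from it by methyl in place of hydrogen on an aromatic carbon, and in this assay compound 2 gives 16000 nM, a step of a 1.3-fold higher number from compound 1 to compound 2 (0.12 log units; within the scatter). Compound 3 `Cc1cc(S(=O)(=O)/N=C(\N)n2nccc2-c2ccccc2)c(SCc2ccccc2C(F)(F)F)cc1Cl` gives 16000 nM in this assay, with a 1.3-fold higher number from compound 1 to compound 3 (0.12 log units; within the scatter) and, against compound 2, no change at the digits printed from compound 2 to compound 3 (within the scatter).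

Compound 4 `Cc1cc(-c2ccccc2)n(/C(N)=N/S(=O)(=O)c2cc(C)c(Cl)cc2SCc2ccccc2C(F)(F)F)n1` is not yet measured. It carries methyl in place of hydrogen on an aromatic carbon. The change from compound 1 to compound 2 is the same kind of change, but the place differs: in compound 2 the methyl sits on an aromatic carbon of a six-membered aromatic ring of carbon only, ortho to a large group, whereas in compound 4 it sits on an aromatic carbon of a five-membered aromatic ring with 2 nitrogen, next to the ring nitrogen. The two cores differ by trifluoromethyl in place of hydrogen on an aromatic carbon.

Because a 1.3-fold higher number from compound 1 to compound 2 (0.12 log units; within the scatter) stayed within the scatter, the step from compound 3 to compound 4 is expected to be about a 1.1-fold higher number from compound 3 to compound 4 (0.03 log units; within the scatter) in this assay. Compound 4 is therefore estimated at 17000 nM, between 8000 nM and 36000 nM.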

Compound 4, half-maximal inhibitory concentration: 25000 nM
Beside the measured number, compound 4's estimate is 1.5-fold (0.17 log units) below it, and the stated range covers the measured number.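

In this assay, methyl in place of hydrogen on an aromatic carbon comes out as a 1.6-fold higher number from compound 3 to compound 4 (0.19 log units; within the scatter), and set beside the earlier step the two agree: the same change on two cores in this assay, a 1.3-fold higher number (0.12 log units; within the scatter) from compound 1 to compound 2 and a 1.6-fold higher number (0.19 log units; within the scatter) from compound 3 to compound 4, 1.2-fold (0.07 log units) apart, within the scatter of two such steps. Across these two pairs, then, the change stays within the scatter on both cores, and nothing indicates that the core alters its size. This does not show that the methyl has any effect of its own in either pair, and it is not a test of one site on two cores, as the methyl sits on a six-membered carbon ring in compound 2 and on a five-membered ring with 2 nitrogen in compound 4.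

The compounds shown leave open whether any other group in place of that methyl, such as an amine, a carboxylic acid or a longer chain, would give a step beyond the scatter. They also leave open how the methyl behaves on cores other than these two.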